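The source may report more compounds than this note shows. Statements on the series, on what has been measured and on what is new or still open speak of the compounds shown alone.

Compound 1, `COc1cccc(C(O)CCn2nc3c(Br)c(Br)c(Br)c(Br)c3n2)c1`, gives 50% in a functional assay on CCRF-CEM cells (Homo sapiens) for antiproliferative activity, read by MTT assay, with a stated time of 48 h, tested at 25 uM; a higher number here means a weaker effect of the compound at the concentration tested, a lower number a stronger effect. Compound 2, `OC(CCn1nc2c(Br)c(Br)c(Br)c(Br)c2n1)c1ccc(Br)cc1`, gives 69%.

Among the measured compounds shown here, compound 2 stands highest of the two numbers in this assay; its only neighbour is compound 1, and the step of a number 19 percentage points higher from compound 1 to compound 2 (beyond the scatter) lies beyond the scatter. Compound 3, `OC(CCn1nc2c(Br)c(Br)c(Br)c(Br)c2n1)c1ccc(Cl)cc1`, differs from compound 2 by chloro in place of bromo on an aromatic carbon. For the measured compounds named here, no measured step tests a halogen swap of this kind; the one known step exchanges whole phenyl groups and so offers no direct guide. A step within the scatter is therefore expected: a number 3 percentage points lower from compound 2 to compound 3 (within the scatter). Compound 3 is expected to give 66%, between 50% and 82%.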

Compound 3, a percentage reported as activity, at one concentration (the size of the read-out at that concentration, not a potency): 69%
Estimate against measurement, compound 3: 3 percentage points below, and the stated range covers the measured number.
By their numbers in this assay, from the lowest: compound 1; then compounds 2 and 3 (each within the scatter of the next).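

At this position, para to a large group, chloro and bromo cannot be told apart in this assay (no change at the digits printed from compound 2 to compound 3 (within the scatter)). The 4-chlorophenyl group also keeps the gap to the 3-methoxyphenyl group (a number 19 percentage points higher from compound 1 to compound 3 (beyond the scatter)), so compound 2 and compound 3 both read as weaker than compound 1 at the concentration tested. No evidence bears on why these numbers fall as they do. A 4-methoxyphenyl group would show whether the gap follows the place of the group or its kind, and a 4-fluorophenyl group would extend the halogen comparison.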